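Compound 4: morpholin-4-yl replacing piperidin-1-yl on compound 2

A few compounds are considered here, and "the series" means these few. Any claim that something is new, unique, unknown or untested is made for them only; others in the source may bear on it.

Within the data shown here, compound 2 `O=c1c(Cl)c(CSC(=S)N2CCCCC2)oc2ccccc12` gives 940 nM in a functional assay on HEp-2 cells (Homo sapiens) for antiproliferative activity, read by MTT assay, with a stated time of 72 h (a lower number here means a stronger inhibitor, a higher number a weaker inhibitor), the lowest of the three numbers so far. Among the measured compounds shown here, compound 1 `O=c1cc(CSC(=S)N2CCCCC2)oc2ccccc12` gives 12000 nM, and the step of a 13-fold lower number from compound 1 to compound 2 (1.11 log units; beyond the scatter) is the only single-place step among the measured compounds. Compound 3 `COc1ccc2oc(CSC(=S)N(C(C)C)C(C)C)cc(=O)c2c1` gives 7600 nM; it differs from compound 1 in two places, so its value stands beside the others without a counted step. Compound 4 `O=c1c(Cl)c(CSC(=S)N2CCOCC2)oc2ccccc12` carries morpholin-4-yl in place of piperidin-1-yl on a thiocarbonyl carbon. For the measured compounds named here, no measured step touches the group on the thiocarbonyl carbon; the chloro step concerns another place and gives no guide here. The expected step of a 1.4-fold higher number from compound 2 to compound 4 (0.14 log units; within the scatter) is therefore small, within the scatter, with a wide range for the unknown direction. Compound 4 is estimated at 1300 nM, between 450 nM and 4000 nM.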

Compound 4, half-maximal inhibitory concentration: 9000 nM
Beside the measured number, compound 4's estimate is 6.9-fold (0.84 log units) below it; measured number above the stated range.
By their numbers in this assay, from the lowest: compound 2; then compounds 3, 4 and 1 (each within the scatter of the next).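

The group on the thiocarbonyl carbon is not a silent place in this assay: morpholin-4-yl in place of piperidin-1-yl gives a 9.6-fold higher number from compound 2 to compound 4 (0.98 log units; beyond the scatter) and so moves the number beyond the scatter. The change keeps the six-membered ring and its heavy-atom count, yet one ring oxygen in place of carbon, with its one hydrogen-bond acceptor, is enough for this step. No measured evidence accounts for the step.

From the compounds shown here alone, whether the same change carries over to the core of compound 1 stays open. Thiomorpholin-4-yl or 4-methylpiperazin-1-yl on the thiocarbonyl carbon would show whether the step is specific to the ring oxygen.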